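Truncation of the tryptophan side chain in the ester series

The source may hold more compounds than are shown below. What is called first, only, known or untested is meant among the compounds shown, and "the series" means these compounds.

Measured compounds in an ADME assay on HeLa cells (Homo sapiens) for cytotoxicity, read by MTT assay; a higher number here means a weaker inhibitor, a lower number a stronger inhibitor:
Compound 1 `COC(=O)[C@@H](NC(=O)CCC(=O)Oc1ccc(C[C@H]2C(=O)OC[C@@H]2Cc2ccc(OC)c(OC)c2)cc1OC)c1c[nH]c2ccccc12` sits at a limit of the assay, >= 600000 nM.
Compound 2 `COc1ccc(C[C@H]2COC(=O)[C@@H]2Cc2ccc(OCc3cn(Cc4ccccc4F)nn3)c(OC)c2)cc1OC` sits at a limit of the assay, >= 600000 nM.
Compound 3 `COc1ccc(C[C@H]2COC(=O)[C@@H]2Cc2ccc(OCc3cn(Cc4ccc(F)cc4)nn3)c(OC)c2)cc1OC` gives 198000 nM.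

Compound 1 stands at the upper limit of this assay, alongside compound 2, as noted in the limit of >= 600000 nM in this assay, at which 2 of the 3 values shown sit; only compound 3 returns a number. Compound 4 `COC(=O)CNC(=O)CCC(=O)Oc1ccc(C[C@H]2C(=O)OC[C@@H]2Cc2ccc(OC)c(OC)c2)cc1OC` differs from compound 1 by hydrogen in place of 1H-indol-3-yl on a saturated chain carbon bound to an amide-type nitrogen and a carbonyl carbon. Going by the values given here, the only measured step, an at least 3.0-fold lower number from compound 2 to compound 3 (0.48 log units; beyond the scatter), concerns a fluorophenyl substituent on a triazole arm that compound 1 does not carry, so it offers no direct guide to this change. With compound 1 already at the limit, no movement beyond the scatter is expected, and compound 4 is estimated at 600000 nM (range 300000 nM to 1200000 nM), which means an expected step of a number no higher from compound 1 to compound 4 (the limit leaves the size open).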

Compound 4, half-maximal inhibitory concentration: 179000 nM
Beside the measured number, compound 4's estimate is 3.4-fold (0.53 log units) above it, outside the stated range (below it).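

In this assay, the saturated chain carbon bound to an amide-type nitrogen and a carbonyl carbon proves sensitive to change: hydrogen in place of 1H-indol-3-yl gives an at least 3.3-fold lower number from compound 1 to compound 4 (0.52 log units; beyond the scatter). Going by these compounds alone, the earlier step concerned only the fluorophenyl arm, so this is the first reading at this position, and it shows that removing 1H-indol-3-yl lowers the number. The full size of the step stays open because compound 1 sits at a limit: the limit of >= 600000 nM in this assay, at which 2 of the 4 values shown sit.

From the compounds shown here alone, whether a methyl group or a longer chain at this carbon would give a number nearer compound 1 or compound 4 remains open. So does the effect of a carboxylic acid in place of the methyl ester.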